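The source may hold more compounds than are shown below. What is called first, only, known or untested is meant among the compounds shown, and "the series" means these compounds.

In a functional assay on SCC-9 cells (Homo sapiens) for antiproliferative activity, read by CCK-8 assay, with a stated time of 5 days (a higher number here means a weaker inhibitor, a lower number a stronger inhibitor), compound 1 `COc1ccc(CCc2nc3cc(-c4c(C)noc4C)ccc3n2[C@H]2CC[C@H](O)CC2)cc1Cl` gives 3680 nM and compound 2 `COc1ccc(N2C(=O)C[C@H]2c2nc3cc(-c4c(C)noc4C)ccc3n2[C@H]2CC[C@H](OC)CC2)cc1Cl` gives 1850 nM as its reading. These two values lie within the scatter of each other, so compound 2 does not stand apart from compound 1 on these numbers. Compound 3 `COc1ccc(N2C(=O)C[C@@H]2c2nc3cc(-c4c(C)noc4C)ccc3n2[C@H]2CC[C@H](OC)CC2)cc1Cl` is now to be read against compound 2, and the change is one of configuration alone: the two compounds have the same atoms and bonds and differ only in configuration as drawn: 2 of 3 stereo elements differ; a stereocentre at a saturated ring carbon is drawn S in compound 2 and R in compound 3; a stereocentre at a saturated ring carbon is drawn S in compound 2 and R in compound 3 is the whole difference between them. Among the compounds with values here, no measured pair here shows what such an inversion does in this assay so its size remains a matter of judgement. A move to a lower number, beyond the scatter, is expected, though a move the other way cannot be excluded. The expected step is a 2.6-fold lower number from compound 2 to compound 3 (0.42 log units; beyond the scatter) on this reading. Compound 3 is expected at 700 nM with an estimated range from 120 nM to 4000 nM when measured.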

Compound 3, half-maximal inhibitory concentration: 3170 nM
For compound 3 the middle estimate is 4.5-fold (0.66 log units) below the measured one; the measured number falls inside the stated range.
By their numbers in this assay, from the lowest: compounds 2, 3 and 1 (each within the scatter of the next).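

In this assay, within the data shown here, this pair gives the first reading of a change of configuration alone, with a 1.7-fold higher number from compound 2 to compound 3 (0.23 log units; within the scatter). On these numbers, inverting the two saturated ring carbons together does not separate the two compounds, something that compound 1 and compound 2, which differ in more than one place, could not show. The comparison is clean, and it rests on one point: the fact that compounds 2 and 3 differ only in the configuration as drawn

Since both stereocentres differ at once, the compounds shown leave open what inverting either one alone would do in this assay. They also leave open whether the same double inversion would read alike in compounds carrying an amine or a carboxylic acid on the shared core.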